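The source may hold more compounds than are shown below. What is called first, only, known or untested is meant among the compounds shown, and "the series" means these compounds.

Compound 1 `COc1cc(C)cc(-c2c(-c3ccnc(-c4ccc(C(C)=O)cc4)c3)cnn2CC#N)c1` gives 23% in a functional assay on SF-268 cells (Homo sapiens) for cytotoxicity, read by sulforhodamine B assay, with a stated time of 48 h, tested at 10 uM; a lower number here means a stronger effect, a higher number a weaker effect of the compound at the concentration tested.
Compound 2 `COc1cc(C)cc(-c2nn(CC#N)cc2-c2ccnc(-c3ccc(N(C)C)cc3)c2)c1` gives -32% in this assay.
Compound 3 `Cc1cc(O)cc(-c2nn(CC#N)cc2-c2ccnc(-c3ccc(N(C)C)cc3)c2)c1` gives -58% in this assay.

Among these three numbers compound 1 stands highest, that is, it shows the weakest effect. Compound 4 `COc1cc(C)cc(-c2c(-c3ccnc(-c4ccc(N(C)C)cc4)c3)cnn2CC#N)c1` is reached from compound 1 by a single change: dimethylamino in place of acetyl on an aromatic carbon. Going by the values given here, the only step measured so far, a number 26 percentage points lower from compound 2 to compound 3 (beyond the scatter), concerns a different position and does not bear on this exchange. Compound 2, which carries the same dimethylamino group, gives -32%, far lower than compound 1, so a drop of similar size is expected here. The estimate for compound 4 is -20% with a range of -60% to 20%, a step of a number 43 percentage points lower from compound 1 to compound 4 (beyond the scatter).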

Compound 4, a percentage reported as activity, at one concentration (the size of the read-out at that concentration, not a potency): 20%
Beside the measured number, compound 4's estimate is 40 percentage points below it, and the stated range covers the measured number.
By their numbers in this assay, from the lowest: compound 3; then compound 2; then compounds 4 and 1 (each within the scatter of the next).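

In this assay the exchange of acetyl for dimethylamino, para to a large group, gives a number 3 percentage points lower from compound 1 to compound 4 (within the scatter) and so the two groups cannot be told apart on this core. Dimethylamino at this place therefore brings no stronger effect here than acetyl does. Nothing at hand explains why these two groups read alike. Still open, from the compounds shown here alone, is whether they would also read alike on the core of compound 2. Also open, going by these compounds, is whether a carboxylic acid or a primary amine at this place would give a different number.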